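This account rests on a few compounds, and the source may have more. Where it says the series, first, only, none or still open, it means among the compounds named here.

In a functional assay on MDA-MB-468 cells (Homo sapiens) for antiproliferative activity (a lower number here means a stronger inhibitor of growth, a higher number a weaker inhibitor of growth), compound 1 `COc1ccc(-c2nc3cc(F)ccc3s2)cc1C` gives 58 nM. Compound 3 `COCOc1ccc(-c2nc3cc(F)ccc3s2)cc1OC`, at 48 nM, cannot be told apart from it within the scatter, whereas compound 2 `Oc1ccc(-c2nc3cc(F)ccc3s2)cc1O`, at 190 nM, is clearly the weaker inhibitor of growth of the two. Compound 4 `CCOc1cc(-c2nc3cc(F)ccc3s2)ccc1OC` departs from compound 1 with ethoxy in place of methyl on an aromatic carbon, ortho to a methoxy group: ethoxy in place of methyl on an aromatic carbon. Compound 3, which also carries oxygen-linked groups on that ring, gives 48 nM, so no step beyond the scatter is expected in this assay. The estimated change is small and toward weaker inhibition: a 1.2-fold higher number from compound 1 to compound 4 (0.08 log units; within the scatter). For compound 4 the expected value is 70 nM, within an estimated range of 22 nM to 220 nM.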

Compound 4, concentration for 50% growth inhibition: 92 nM
The estimate for compound 4 lay 1.3-fold (0.12 log units) below the measured number; low and high end bracket the measured number.
By their numbers in this assay, from the lowest: compounds 3, 1 and 4 (each within the scatter of the next); then compound 2.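

In this assay, ethoxy in place of methyl on an aromatic carbon, ortho to a methoxy group, gives a 1.6-fold higher number from compound 1 to compound 4 (0.20 log units; within the scatter) and so leaves the number unresolved from that of compound 1. This position thus accepts the larger ethoxy group, with its added oxygen, without a step beyond the scatter. Nothing available explains the size of this step. The compounds shown leave open how an amine, a carboxylic acid or a longer alkoxy chain would fare at this position.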